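The source may hold more compounds than are shown below. What is called first, only, known or untested is meant among the compounds shown, and "the series" means these compounds.

Of the compounds shown here, three built on one shared core have been measured in an assay for inhibition of Fatty-acid amide hydrolase 1 (Rattus norvegicus); a higher number here means a weaker inhibitor, a lower number a stronger inhibitor. Compound 1 `O=C(CCCCC#Cc1ccncc1)c1ncc(-c2ccccn2)o1` gives 150 nM. Compound 3 `O=C(CCCCCCc1cccc2ccccc12)c1ncc(-c2ccccn2)o1` gives 2.6 nM. Compound 2 `COC(=O)c1ccccc1CCCCCCC(=O)c1ncc(-c2ccccn2)o1` gives 1 nM, the lowest of the three numbers and beyond the scatter relative to both others, so compound 2 is the strongest inhibitor among them. A further compound, compound 4 `CSc1ccccc1CCCCCCC(=O)c1ncc(-c2ccccn2)o1`, differs from compound 2 in a single place: methylsulfanyl in place of methoxycarbonyl on an aromatic carbon. Among the measured compounds shown here, no measured pair shows this kind of change, so the outlook rests on the three values alone. A small rise in the number, or none beyond the scatter, is expected. For compound 4 a value near 3 nM is expected, within 1 nM to 10 nM. This expectation amounts to a step of a 3.0-fold higher number from compound 2 to compound 4 (0.48 log units; beyond the scatter).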

Compound 4, inhibition constant: 3.3 nM
Beside the measured number, compound 4's estimate is 1.1-fold (0.04 log units) below it; measured number inside the range.
By their numbers in this assay, from the lowest: compound 2; then compounds 3 and 4 (each within the scatter of the next); then compound 1.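

In this assay, replacing methoxycarbonyl with methylsulfanyl on this aromatic carbon gives a 3.3-fold higher number from compound 2 to compound 4 (0.52 log units; beyond the scatter) and so costs some potency, though only a modest amount. The position therefore accepts a smaller group with one hydrogen-bond acceptor fewer and no double bond outside the ring, and methoxycarbonyl is not essential for strong inhibition. No measurement shown here accounts for the size of this step. From the compounds shown here alone, how a carboxylic acid or an amine on this same carbon would compare remains open. So does whether this swap would give a similar step on a longer chain.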